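Aryl halogen change from compound 1 to compound 3

The compounds below may be only part of what the source reports. "The series", "measured", "known", "first", "only" and "open" are said of these compounds alone.

Measured so far:
compound 1 `Cc1ncc([N+](=O)[O-])n1CCOc1ccccc1`: 106 ug/mL
compound 2 `Cc1ncc([N+](=O)[O-])n1CCOc1ccc(F)cc1`: 85.8 ug/mL

In a functional assay on MCF7 cells (Homo sapiens) for cytotoxicity, read by MTT assay, with a stated time of 24 h (a higher number here means a weaker inhibitor, a lower number a stronger inhibitor), compound 1 gives 106 ug/mL, the highest of the two numbers in hand; its nearest neighbour is compound 2, and the step of a 1.2-fold lower number from compound 1 to compound 2 (0.09 log units; within the scatter) lies within the scatter, so the two compounds cannot be ordered. Compound 3 `Cc1ncc([N+](=O)[O-])n1CCOc1ccccc1Cl` differs from compound 1 by chloro in place of hydrogen on an aromatic carbon. Going by the values given here, the only measured step that bears on this change is the halogen step a 1.2-fold lower number from compound 1 to compound 2 (0.09 log units; within the scatter), which did not move the number beyond the scatter. On that basis no step beyond the scatter is expected for compound 3 in this assay, in either direction. The estimate for compound 3 is 90 ug/mL, with a range from 50 ug/mL to 160 ug/mL. This expected value means a step of a 1.2-fold lower number from compound 1 to compound 3 (0.07 log units; within the scatter), which is expected to stay within the scatter.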

Compound 3, half-maximal inhibitory concentration: 378 ug/mL
Estimate against measurement, compound 3: 4.2-fold (0.62 log units) below; measured number above the stated range.
By their numbers in this assay, from the lowest: compounds 2 and 1 (each within the scatter of the next); then compound 3.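

In this assay, a halogen on the aromatic ring does not always leave the number within the scatter: chloro in place of hydrogen, ortho to a large group, gives a 3.6-fold higher number from compound 1 to compound 3 (0.55 log units; beyond the scatter), while the earlier fluoro change gave only a 1.2-fold lower number from compound 1 to compound 2 (0.09 log units; within the scatter). Going by these compounds alone, this is the first change that moves the number beyond the scatter, and it moves towards weaker inhibition. No measurement in hand accounts for this step.

Compound 2 and compound 3 differ in more than one place, so the identity of the halogen and its place on the ring cannot be separated here. As far as these compounds go, it also remains open whether fluoro, bromo, methoxy or an amine ortho to the same large group would give a step like that of chloro.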